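A few compounds are considered here, and "the series" means these few. Any claim that something is new, unique, unknown or untested is made for them only; others in the source may bear on it.

Compound 1, `CCOC(=O)C1=C(Nc2ccccc2)S/C(=C\c2cccc(C(=O)O)c2)C1=O`, is the reference point of this account. In a functional assay on JAR cells (Homo sapiens) for inhibition, read by MTT assay, with a stated time of 72 h, tested at 10 uM (on this read-out lower numbers stand for less inhibition and higher numbers for more inhibition at the one concentration tested (going by the name of the read-out)), compound 1 gives 50.6%, the highest of the three numbers at hand. Compound 3, `CCOC(=O)C1=C(Nc2ccc(OC)c(OC)c2)S/C(=C\c2ccc[nH]2)C1=O`, gives 47.9%, a result that stays within the scatter of compound 1, so no order between them can be claimed. Compound 2, `CCOC(=O)C1=C(Nc2ccccc2)S/C(=C\c2cc(OC)ccc2OC)C1=O`, gives 38.1%, which lies beyond the scatter below compound 1.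

Compound 4, `CCOC(=O)C1=C(Nc2ccccc2)S/C(=C\c2cc3cccnc3[nH]2)C1=O`, has not yet been measured. It differs from compound 1 by one change: a group of 9 heavy atoms (7 carbon, 2 nitrogen; one five-membered aromatic ring with 1 hetero atom, one six-membered aromatic ring with 1 hetero atom) in place of a group of 9 heavy atoms (7 carbon, 2 oxygen; one six-membered aromatic ring of carbon only), on a double-bonded chain carbon bound to a double-bonded ring carbon. The group that enters brings a five-membered aromatic ring with 1 hetero atom, a feature that compound 3 also carries, and compound 3 stays close to compound 1 in this assay.

Among the compounds with values here, no step between measured compounds exists for this change, so the expectation rests on the spread of the three numbers. Compound 4 is estimated to give 46%, with a range from 28% to 64%. The step that this estimate means, a number 4.6 percentage points lower from compound 1 to compound 4 (within the scatter), is expected to fall within the scatter rather than beyond it in either direction.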

Compound 4, a percentage reported as inhibition, at one concentration (the size of the read-out at that concentration, not a potency): 54.3%
For compound 4 the middle estimate is 8.3 percentage points below the measured one; the measured number falls inside the stated range.
By their numbers in this assay, from the lowest: compounds 2, 3, 1 and 4 (each within the scatter of the next, the first and the last beyond it).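

At the double-bonded chain carbon bound to a double-bonded ring carbon, the 3-carboxyphenyl group can be exchanged for a group carrying a five-membered and a six-membered aromatic ring, each with 1 hetero atom, and in this assay this gives a number 3.7 percentage points higher from compound 1 to compound 4 (within the scatter). Within the data shown here, this is the first direct exchange at this place, and it shows that in this pair the read-out holds up without a carboxyphenyl group, although the two groups differ in their rings and hetero atoms. No measured property of either group accounts for this result.

As far as these compounds go, whether a plain phenyl, a 3-aminophenyl or a longer chain ending in a carboxylic acid would fare the same at this place remains open. The read-out at one concentration also leaves the potency of compound 1 and compound 4 open.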